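Trimming an Amide Substituent in a Kinase Inhibitor Series

The source may hold more compounds than are shown below. What is called first, only, known or untested is meant among the compounds shown, and "the series" means these compounds.

Measured compounds:
Compound 1, `CC[C@@H]1C(=O)N(C)c2cnc(-n3ccc4cc(F)ccc43)nc2N1C1CCCC1`: 969 nM
Compound 2, `CCCNC(=O)c1ccc2c(ccn2-c2ncc3c(n2)N(c2ccn(C)n2)C(CC)C(=O)N3C)c1`: 207 nM

Of the compounds shown here, two have so far been measured in an assay for inhibition of serine/threonine-protein kinase PLK2 (Homo sapiens), read by FRET and Z'-LYTE, with a stated time of 1 h; on this read-out lower numbers stand for stronger inhibition and higher numbers for weaker inhibition. Compound 1 `CC[C@@H]1C(=O)N(C)c2cnc(-n3ccc4cc(F)ccc43)nc2N1C1CCCC1` gives 969 nM. Compound 2 `CCCNC(=O)c1ccc2c(ccn2-c2ncc3c(n2)N(c2ccn(C)n2)C(CC)C(=O)N3C)c1` gives 207 nM, which is the lowest of the two numbers; compound 1 stands at a higher number, and that gap lies beyond the usual scatter. The two measured compounds differ in several places at once, so no single structural step can be read off between them.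

Compound 3 `CCC1C(=O)N(C)c2cnc(-n3ccc4cc(C(N)=O)ccc43)nc2N1c1ccn(C)n1` is the compound to be measured next. It differs from compound 2 in one place only: hydrogen in place of propyl on an amide-type nitrogen. Among the measured compounds shown here, nothing among the measured compounds shows what this particular change does, so the expectation rests on the change itself: a small step, if any, most likely toward a somewhat higher number, with a real chance that it stays within the scatter. Compound 3 is therefore expected to give 350 nM, with a range from 120 nM to 1000 nM. The step from compound 2 to compound 3 that this estimate means is a 1.7-fold higher number from compound 2 to compound 3 (0.23 log units; within the scatter).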

Compound 3, half-maximal inhibitory concentration: 384 nM
For compound 3 the middle estimate is 1.1-fold (0.04 log units) below the measured one, and the stated range covers the measured number.
By their numbers in this assay, from the lowest: compounds 2 and 3 (each within the scatter of the next); then compound 1.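

Among the compounds shown here, replacing the propyl on the amide-type nitrogen with hydrogen, which turns the propylcarbamoyl group into a plain carbamoyl group, gives in this assay a 1.9-fold higher number from compound 2 to compound 3 (0.27 log units; within the scatter) and thus provides the first comparison in this set that changes only one place. At this position, then, the whole propyl chain can be removed without a change that this read-out can separate from the ordinary spread of repeated measurements, so compound 3 and compound 2 cannot be ranked, and the propyl chain is not required to keep the number in this range. Nothing available explains why the two compounds read alike.

As far as these compounds go, a single step cannot show how far this tolerance extends, so it remains open whether a methyl, a longer chain such as butyl, or a carboxylic acid in place of the whole carbamoyl group would move the number beyond the scatter. Compound 1 differs from compound 3 in more than one place, so the gap between them cannot be assigned to any one group.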